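Benzyl in Place of Acetyl on Compound 1

A few compounds are considered here, and "the series" means these few. Any claim that something is new, unique, unknown or untested is made for them only; others in the source may bear on it.

In a functional assay on MCF7 cells (Homo sapiens) for antiproliferative activity, read by MTT assay, with a stated time of 72 h (on this read-out lower numbers stand for stronger inhibition and higher numbers for weaker inhibition), compound 1 `CC(=O)O[C@H]1CC[C@]2(C)[C@H](CC[C@@](C)(O)[C@H]2CC[C@@H]2C(C)=CC[C@H]3[C@H](CC[C@]3(C)O)C2(C)C)OC1(C)C` gives 47900 nM and sits at the high end of the three numbers measured. Compound 2 `CC(=O)O[C@H]1CC[C@]2(C)[C@H](CC[C@@](C)(O)[C@H]2CC[C@@H]2C(C)=CC[C@H]3[C@H](CC[C@]3(C)OC(C)=O)C2(C)C)OC1(C)C` at 39200 nM shares that end with it, while compound 3 `CC1=CC[C@H]2[C@@H]1CC=C(C)[C@@H](CC[C@H]1[C@]3(C)CC[C@H](OC(=O)c4ccccc4)C(C)(C)O[C@H]3CC[C@@]1(C)O)C2(C)C` at 23100 nM lies clearly lower than compound 1.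

Compound 4 `CC1=CC[C@H]2[C@H](CC[C@]2(C)O)C(C)(C)[C@@H]1CC[C@H]1[C@]2(C)CC[C@H](OCc3ccccc3)C(C)(C)O[C@H]2CC[C@@]1(C)O` is compound 1 with benzyl in place of acetyl on an oxygen on a saturated carbon, a change counted as benzyl in place of acetyl on an oxygen on a saturated carbon and still unmeasured. Among the measured compounds shown here, the one measured step near this change is a 1.2-fold lower number from compound 1 to compound 2 (0.09 log units; within the scatter) with acetyl in place of hydrogen on an oxygen on a saturated carbon, and it stays within the scatter. For the measured compounds named here, compound 3 at 23100 nM also carries a six-membered aromatic ring of carbon only, yet no single-place step joins it to compound 1, so it offers only a weak hint of a lower number.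

What is expected is therefore a small move downward, a 1.6-fold lower number from compound 1 to compound 4 (0.20 log units; within the scatter) and not clearly beyond the scatter. For compound 4 the estimate is 30000 nM with an expected range from 12000 nM to 60000 nM for the measurement still to come.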

Compound 4, half-maximal inhibitory concentration: > 50000 nM
Compound 4 gave a limit, no number; the forecaster's own chance of this, stated with the estimate: 15%; middle value at least 1.6-fold (0.22 log units) from the limit.
By their numbers in this assay, from the lowest: compounds 3, 2 and 1 (each within the scatter of the next, the first and the last beyond it). At a limit, above all of these: compound 4.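

In this assay, compound 4 gives > 50000 nM, which is a limit of the assay and not a number. Benzyl is the first group shown on this oxygen without a carbonyl, and the change reads as an at least 1.0-fold higher number from compound 1 to compound 4 (0.01 log units; that floor lies within the scatter), so its floor does not separate the two compounds. What it does show is that this change gave no measured value at all in this read-out, and the step therefore rests on a limit rather than on two numbers: the limit of > 50000 nM in this assay, at which 1 of the 4 values shown sits.

Going by these compounds, how far the true value of compound 4 lies from that of compound 1 remains open. Also open, on these data alone, is how this position would respond to a free hydroxyl, an amine or a longer alkyl chain on the shared core.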